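From a dichloro limit compound to a methylated analogue

The source may hold more compounds than are shown below. What is called first, only, known or untested is meant among the compounds shown, and "the series" means these compounds.

Values in an ADME assay on A549 cells (Homo sapiens) for inhibition, read by MTT assay (on this read-out higher numbers stand for weaker inhibition of growth and lower numbers for stronger inhibition of growth), so far:
- Compound 1 `Cc1nc(C)c(-c2nn(-c3ccc(F)cc3)cc2/C=C/C(=O)c2cc(Cl)ccc2O)s1` gives > 250 ug/mL as a limit
- Compound 2 `Cc1ccc(O)c(C(=O)/C=C/c2cn(-c3ccc(F)cc3)nc2-c2sc(C)nc2C)c1` gives 47.8 ug/mL as a number
- Compound 3 `Cc1nc(C)c(-c2nn(-c3ccc(F)cc3)cc2/C=C/C(=O)c2cc(Cl)cc(Cl)c2O)s1` gives > 250 ug/mL as a limit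

Compound 3 stands at > 250 ug/mL which is a limit and not a number. It shares the limit of > 250 ug/mL in this assay, at which 2 of the 3 values shown sit, with compound 1, so its exact position cannot be read. Compound 4 `Cc1nc(C)c(-c2nn(-c3ccc(F)cc3)cc2/C=C/C(=O)c2c(O)cc(C)c(Cl)c2C)s1` differs from compound 3 by 3-chloro-6-hydroxy-2,4-dimethylphenyl in place of 3,5-dichloro-2-hydroxyphenyl on a carbonyl carbon on the same carbonyl carbon. Among the compounds with values here, two measured steps bear on this change. Methyl in place of chloro gave an at least 5.2-fold lower number from compound 1 to compound 2 (0.71 log units; beyond the scatter) and the dichloro group in place of the methyl group gave an at least 5.2-fold higher number from compound 2 to compound 3 (0.71 log units; beyond the scatter) on the same core. The third step, a step that the two limits leave unreadable from compound 1 to compound 3 in the account, adds nothing readable. The entering group carries methyl but keeps a chloro, so only a partial move towards compound 2 is expected, and a result at the limit remains possible. The expected change is an at least 2.0-fold lower number from compound 3 to compound 4 (0.31 log units; beyond the scatter) in this assay overall. For compound 4 the estimated value is 120 ug/mL with an expected range from 40 ug/mL to 350 ug/mL in this measurement.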

Compound 4, concentration for 50% growth inhibition: 33.5 ug/mL
For compound 4 the middle estimate is 3.6-fold (0.55 log units) above the measured one, outside the stated range (below it).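

At the carbonyl carbon, 3-chloro-6-hydroxy-2,4-dimethylphenyl leaves the limit in this assay even though it keeps a chloro, giving an at least 7.4-fold lower number from compound 3 to compound 4 (0.87 log units; beyond the scatter) and an at least 7.4-fold lower number from compound 1 to compound 4 (0.87 log units; beyond the scatter). A chloro on this ring therefore does not by itself hold a compound at the limit, and compound 4 goes against any such rule drawn from compound 1 and compound 3. Against the chloro-free 2-hydroxy-5-methylphenyl group, the change gives a 1.4-fold lower number from compound 2 to compound 4 (0.15 log units; within the scatter), which lies within the scatter, so these two compounds cannot be ordered.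

The full size of the steps from compound 1 and compound 3 stays open because both values are limits: the limit of > 250 ug/mL in this assay, at which 2 of the 4 values shown sit. The compounds shown also do not separate the part played by each methyl group, and they leave open how a methoxy group or an amine on this ring would read.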